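Sulfonylation of the Ring Amine in a Macrocyclic Peptide

The compounds below may be only part of what the source reports. "The series", "measured", "known", "first", "only" and "open" are said of these compounds alone.

Measured compounds:
- compound 1, `CC[C@H](C)[C@H](NC(=O)[C@H]1Cc2ccc(O)c(c2)CC=CCNCCCC[C@H](N)C(=O)N[C@@H](CCCCN)C(=O)N2CCC[C@H]2C(=O)N1)C(=O)N[C@@H](CC(C)C)C(=O)O`, 0.317 h
- compound 2, `CC[C@H](C)[C@H](NC(=O)[C@H]1Cc2ccc(O)c(c2)CC=CCCCCCC[C@](C)(N)C(=O)N[C@@H](CCCCN)C(=O)N2CCC[C@H]2C(=O)N1)C(=O)N[C@@H](CC(C)C)C(=O)O`, 24 h
- compound 3, `CC[C@H](C)[C@H](NC(=O)[C@H]1Cc2ccc(O)c(c2)CC=CCNCCCC[C@@H](N)C(=O)N[C@@H](CCCCN)C(=O)N2CCC[C@H]2C(=O)N1)C(=O)N[C@@H](CC(C)C)C(=O)O`, 24 h

Of the compounds shown here, three sharing one macrocyclic core have been measured in an ADME assay on a cell-free system (plasma, Rattus norvegicus) for metabolic stability, read by HPLC; on this read-out lower numbers stand for a shorter-lived compound and higher numbers for a longer-lived compound. Compound 1 stands lowest of the three; compound 2 and compound 3 both sit far above it, each at the same number. Going by the values given here, the only step between compounds that differ in one place is a 76-fold higher number from compound 1 to compound 3 (1.88 log units; beyond the scatter); the evidence beside that step is the fact that one of compounds 1 and 3 is drawn with a defined configuration and the other without, at the place where they differ, which concerns how a stereocentre is drawn rather than any change of atoms.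

The step under consideration leads from compound 1 to compound 4, `CC[C@H](C)[C@H](NC(=O)[C@H]1Cc2ccc(O)c(c2)CC=CCN(S(=O)(=O)c2ccccc2[N+](=O)[O-])CCCC[C@H](N)C(=O)N[C@@H](CCCCN)C(=O)N2CCC[C@H]2C(=O)N1)C(=O)N[C@@H](CC(C)C)C(=O)O`. The change is (2-nitrophenyl)sulfonyl in place of hydrogen on an amine nitrogen in a ring. Among the compounds with values here, no measured step touches that amine nitrogen, so none of the recorded steps bears directly on this change, and the large step from compound 1 to compound 3 says nothing about it. Within the data shown here, with no guiding step, the expectation for compound 4 in this assay rests on compound 1 alone and carries a wide range: compound 4 is estimated at 0.8 h, between 0.2 h and 5 h. That estimate means a step of a 2.5-fold higher number from compound 1 to compound 4 (0.40 log units; beyond the scatter), expected to lie within the scatter.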

Compound 4, half-life: 1.4 h
Compound 4: middle estimate off by 1.8-fold (0.24 log units), on the low side; the range from low to high includes it.
By their numbers in this assay, from the lowest: compound 1; then compound 4; then compounds 2 and 3 (each within the scatter of the next).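

In this assay, the amine nitrogen in the ring proves open to substitution: (2-nitrophenyl)sulfonyl in place of hydrogen gives a 4.4-fold higher number from compound 1 to compound 4 (0.65 log units; beyond the scatter). Going by these compounds alone, this is the first measured change at this nitrogen, and it shows that a group of this size can sit there without the number falling; the rise is modest but beyond the scatter. Within the data shown here, nothing recorded accounts for the rise, since the only available evidence concerns how a stereocentre is drawn and not this nitrogen.

The compounds shown leave open whether the sulfonyl link or the nitro-bearing aromatic ring carries the step, which a plain methyl, an acetyl or a methanesulfonyl group on the same nitrogen could help to separate. They also leave open whether the same group would give a similar step on the core of compound 3.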